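Cyano for Trifluoromethyl: Expected Blood Half-Life of Compound 3

The source may report more compounds than this note shows. Statements on the series, on what has been measured and on what is new or still open speak of the compounds shown alone.

Compound 1 `COC(=O)CCNC(=O)[C@@H]1O[P@](=O)(Oc2ccc(C(F)(F)F)cc2)OCC1(C)C`: > 1 h
Compound 2 `COC(=O)CCNC(=O)[C@@H]1O[P@](=O)(OCOC(=O)c2ocnc2C)OCC1(C)C`: 0.27 h

In an ADME assay on blood (Homo sapiens) for pharmacokinetics (a lower number here means that the compound disappears faster, a higher number that the compound lasts longer), compound 1 reaches only a limit of the assay, > 1 h, not a number. That limit, (the limit of > 1 h in this assay, at which 1 of the 2 values shown sits), is all that is known of compound 1. Compound 2 gives 0.27 h in this assay, a plain number.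

Compound 3 `COC(=O)CCNC(=O)[C@@H]1O[P@](=O)(Oc2ccc(C#N)cc2)OCC1(C)C` differs from compound 1 by cyano in place of trifluoromethyl on an aromatic carbon. For the measured compounds named here, no measured pair shows this change, so the step from compound 1 to compound 3 is expected to be none beyond the scatter, a step that the limit leaves unreadable from compound 1 to compound 3. Compound 3 is therefore expected at 1.5 h, within 0.7 h to 4 h, and may again come out as a limit.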

Compound 3, half-life: 0.46 h
Compound 3: the middle estimate sits 3.3-fold (0.51 log units) above what was measured; measured number below the stated range.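

At this place on the aromatic ring, the group matters for how long the compound lasts in this assay: cyano in place of trifluoromethyl gives an at least 2.1-fold lower number from compound 1 to compound 3 (0.33 log units; beyond the scatter). A swap of one small group on an aromatic carbon, with the rest of the molecule unchanged, is thus enough to move the half-life beyond the scatter. The full size of the step stays unknown, as compound 1 is only a limit: the limit of > 1 h in this assay, at which 1 of the 3 values shown sits.

Going by these compounds, how an amine or a methoxy group at this place would fare remains open. So does whether the same change would act alike on another core.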